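This account rests on a few compounds, and the source may have more. Where it says the series, first, only, none or still open, it means among the compounds named here.

Measured so far in the series:
compound 1 `Cc1cc(C)c2cccc(OCc3c(Cl)ccc(S(=O)(=O)NC4(C(=O)N5CCN(C(=O)[C@@H](N)CCCC[N+](C)(C)C)CC5)CCCC4)c3Cl)c2n1` — < 10000 nM
compound 2 `Cc1cc(C)c2cccc(OCc3c(Cl)ccc(S(=O)(=O)NC4(C(=O)N5CCN(C(=O)[C@@H](N)CC[N+](C)(C)C)CC5)CCCC4)c3Cl)c2n1` — < 10000 nM

In an assay on isolated protein for binding affinity to B1 bradykinin receptor (Homo sapiens) (on this read-out higher numbers stand for weaker inhibition and lower numbers for stronger inhibition), compound 1 gives < 10000 nM; this is a limit of the assay, not a number. In this assay compound 2 gives < 10000 nM, likewise a limit. Compound 1 therefore stands at the limit and at no point on a numbered scale, which is the whole of what is known: the limit of < 10000 nM in this assay, at which 2 of the 2 values shown sit. Among the measured compounds shown here, the single measured step, a step that the two limits leave unreadable from compound 1 to compound 2, cannot be read for size or direction for the same reason.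

Compound 3 `Cc1cc(C)c2cccc(OCc3c(Cl)ccc(S(=O)(=O)NC4(C(=O)N5CCN(C(=N)NCCC[N+](C)(C)C)CC5)CCCC4)c3Cl)c2n1` differs from compound 1 as follows: a group of 10 heavy atoms (7 carbon, 3 nitrogen; no ring) in place of a group of 12 heavy atoms (9 carbon, 2 nitrogen, 1 oxygen; no ring), on an amine nitrogen in a ring.

For the measured compounds named here, no measured step bears on this change; the step from compound 1 to compound 2 touches the saturated chain rather than the amine nitrogen in the ring, and is itself unreadable. Nothing in the data supports expecting a step beyond the scatter in this assay in either direction. Compound 3 is estimated at 1000 nM, with a range from 50 nM to 10000 nM. The expected step is a step that the limit leaves unreadable from compound 1 to compound 3, and a further limit-only result is considered likely.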

Compound 3, inhibition constant: < 10000 nM
Compound 3 was reported as a limit; the forecaster's own chance of this, stated with the estimate: 65%; the middle value lies beyond the limit too.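

In this assay compound 3 gives < 10000 nM, which is a limit and not a number. The steps to compound 3 from compound 1 and from compound 2 therefore cannot be read, and all three compounds share one position: the limit of < 10000 nM in this assay, at which 3 of the 3 values shown sit. Where compound 1, compound 2 and compound 3 lie on a numbered scale, and how either change affects binding affinity, remains open.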